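Five-membered ring returns to the core in compound 4

This account rests on a few compounds, and the source may have more. Where it says the series, first, only, none or still open, it means among the compounds named here.

Compound 3 `Cc1ccc(-c2cnc(Nc3ccc(C#N)cc3)nc2Oc2c(C)cc(C#N)cc2C)cc1` gives 26100 nM in an ADME assay on MT4 cells (Homo sapiens) for cytotoxicity, read by MTT assay, with a stated time of 5 days; on this read-out higher numbers stand for lower toxicity in this test and lower numbers for higher toxicity in this test. Among the three numbers measured it stands second highest: compound 2 `Cc1cc(C#N)cc(C)c1Oc1nc(Nc2ccc(C#N)cc2)ncc1-c1ccccc1` sits nearest with 31800 nM, a gap that lies within the scatter, while compound 1 `Cc1cc(C#N)cc(C)c1Oc1nc(Nc2ccc(C#N)cc2)ncc1-c1cccs1`, the only member so far carrying a five-membered ring on the core, gives 6430 nM, and the step of a 4.1-fold higher number from compound 1 to compound 3 (0.61 log units; beyond the scatter) lies beyond the scatter.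

Compound 4 `Cc1cc(C#N)cc(C)c1Oc1nc(Nc2ccc(C#N)cc2)ncc1-c1ccoc1` differs from compound 3 in one place: furan-3-yl in place of 4-methylphenyl on an aromatic carbon.

Among the measured compounds shown here, two measured steps bear on this change, since both exchanged a five-membered heteroaryl for a six-membered aryl at the same place on the core: a 4.9-fold higher number from compound 1 to compound 2 (0.69 log units; beyond the scatter) and a 4.1-fold higher number from compound 1 to compound 3 (0.61 log units; beyond the scatter). Compound 4 goes the other way, back to a five-membered ring with one hetero atom, though the ring and its attachment are not those of compound 1, and no measurement speaks to that particular ring. A modest downward step in this assay is therefore expected, of about a 2.2-fold lower number from compound 3 to compound 4 (0.34 log units; beyond the scatter), with wide bounds. Compound 4 is estimated at 12000 nM, between 4000 nM and 40000 nM.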

Compound 4, half-maximal cytotoxic concentration: 4980 nM
Estimate against measurement, compound 4: 2.4-fold (0.38 log units) above, and the stated range covers the measured number.
By their numbers in this assay, from the lowest: compounds 4 and 1 (each within the scatter of the next); then compounds 3 and 2 (each within the scatter of the next).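

In this assay, the split seen with the thiophen-2-yl of compound 1 now recurs with a second five-membered ring: furan-3-yl gives lower numbers than both six-membered aryl groups (a 5.2-fold lower number from compound 3 to compound 4 (0.72 log units; beyond the scatter); a 6.4-fold lower number from compound 2 to compound 4 (0.81 log units; beyond the scatter)), and none of the four compounds goes against this. The exchange of thiophen-2-yl for furan-3-yl (a 1.3-fold lower number from compound 1 to compound 4 (0.11 log units; within the scatter)) stays within the scatter, so neither the change of hetero atom nor the change of attachment separates these two compounds here, although the two changes cannot be told apart in this single step. No measured evidence bears on why the five-membered rings give the lower numbers.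

Still open, as far as these compounds go, is whether ring size or the carbon-only aromatic ring tracks with these numbers, which a pyridine ring at this position could test. A non-aromatic group such as morpholine or a simple amine would show whether an aromatic ring is needed here at all.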